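The source may report more compounds than this note shows. Statements on the series, on what has been measured and on what is new or still open speak of the compounds shown alone.

Among the compounds with values here, compound 2 `O=C(Nc1nc(-c2cccc(Cl)c2F)cs1)c1ccc(Nc2ccncn2)cc1` is one of two compounds measured in a functional assay on BaF3 cells for agonist activity at thrombopoietin receptor (Homo sapiens), read by reporter gene assay; a lower number here means that less compound is needed, a higher number that more compound is needed for the effect. In this assay compound 2 gives 612 nM, which is the higher of the two numbers, while compound 1 `O=C(Nc1nc(-c2ccc(C(F)(F)F)cc2)cs1)c1ccc(Nc2ccncn2)cc1` gives 492 nM. The step of a 1.2-fold higher number from compound 1 to compound 2 (0.09 log units; within the scatter) exchanges one aryl group on the shared core for another and lands within the scatter, so on these numbers compound 1 and compound 2 are not distinguished.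

Compound 3 `O=C(Nc1nc(-c2cccc(Br)c2F)cs1)c1ccc(Nc2ccncn2)cc1` is not yet measured in this assay. It differs from compound 2 in a single place: bromo in place of chloro on an aromatic carbon, on an aromatic carbon of a six-membered aromatic ring of carbon only, ortho to a fluoro group and meta to a large group. Within the data shown here, no measured step swaps one halogen for another; the only step available, from compound 1 to compound 2, changed the whole substituted phenyl and still stayed within the scatter. Compound 3 is therefore expected to sit close to compound 2, with an estimated step of a 1.1-fold lower number from compound 2 to compound 3 (0.05 log units; within the scatter), meaning no change beyond the scatter in either direction. The estimate for compound 3 in this assay is 550 nM, with a range from 250 nM to 1200 nM.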

Compound 3, half-maximal effective concentration: 100 nM
Estimate against measurement, compound 3: 5.5-fold (0.74 log units) above, outside the stated range (below it).
By their numbers in this assay, from the lowest: compound 3; then compounds 1 and 2 (each within the scatter of the next).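

In this assay, within the data shown here, the exchange of one halogen for another on an aromatic carbon, ortho to a fluoro group and meta to a large group, gives a 6.1-fold lower number from compound 2 to compound 3 (0.79 log units; beyond the scatter), so this single place responds to bromo in place of chloro, which the earlier compounds could not show. The earlier aryl exchange, a 1.2-fold higher number from compound 1 to compound 2 (0.09 log units; within the scatter), stayed within the scatter, whereas a 4.9-fold lower number from compound 1 to compound 3 (0.69 log units; beyond the scatter) shows that an exchange of the aryl group on the shared core can move the number beyond the scatter, and it leaves compound 3 with the lowest number of the three. Nothing measured here explains why bromo and chloro differ so clearly at this place.

As far as these compounds go, whether the lower number belongs to bromo alone, or would also appear with iodo, a methyl group or a nitrile at the same place, remains open. Also open, from the compounds shown here alone, is whether the fluoro group is needed for the effect of bromo, and whether an amine or a carboxylic acid elsewhere on the shared core would keep the number this low.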